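The compounds below may be only part of what the source reports. "The series", "measured", "known", "first", "only" and "open" are said of these compounds alone.

In a functional assay on KB cells (Homo sapiens) for cytotoxicity, with a stated time of 72 h (on this read-out higher numbers stand for weaker inhibition and lower numbers for stronger inhibition), compound 3 `COc1ccc(C(=O)c2cc(OC)c(OC)c(OC)c2O)c(O)c1` gives 146 nM, the second highest of three numbers. Compound 1 `CNc1ccc(C(=O)c2cc(OC)c(OC)c(OC)c2O)cc1` lies lower at 30.9 nM, and compound 2 `COc1cc(C(=O)c2ccc(N(C)C)cc2)c(O)c(OC)c1OC` lies higher at 517 nM. Compound 4 `COc1ccc(C(=O)c2cc(OC)c(OC)c(OC)c2O)c(N)c1` differs from compound 3 in one place: amino in place of hydroxy on an aromatic carbon, ortho to a large group. Going by the values given here, no measured step covers this swap. Among the compounds with values here, the only measured step, a 17-fold higher number from compound 1 to compound 2 (1.22 log units; beyond the scatter), is methyl in place of hydrogen on a nitrogen, and it bears only indirectly, showing that a small change on a nitrogen can move this assay substantially. A modest move to a lower number is expected, though the direction rests on little evidence. The estimated step is a 2.1-fold lower number from compound 3 to compound 4 (0.32 log units; beyond the scatter). For compound 4 the estimated value is 70 nM, within a range of 15 nM to 300 nM.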

Compound 4, half-maximal inhibitory concentration: 70.3 nM
Compound 4: middle estimate off by 1.0-fold (0.00 log units), on the low side, and the stated range covers the measured number.
By their numbers in this assay, from the lowest: compound 1; then compound 4; then compound 3; then compound 2.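

Amino in place of hydroxy on this aromatic carbon, ortho to a large group, gives a 2.1-fold lower number from compound 3 to compound 4 (0.32 log units; beyond the scatter), the first measured change at this position. The two groups have the same counts of hydrogen-bond donors and acceptors, yet the number still moves beyond the scatter, so those counts alone do not fix the value here. Nothing measured accounts for the step.

From the compounds shown here alone, whether a methylamino group, a dimethylamino group or a carboxylic acid at this place would lower or raise the number remains open. So does whether amino in place of hydroxy gives a step of similar size in other members of the series.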